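The source may hold more compounds than are shown below. What is called first, only, known or untested is meant among the compounds shown, and "the series" means these compounds.

Working notes on the sulfamate series. Three compounds share one core and differ only in the amino group on the aromatic carbon of the pendant ring. Compound 1 `CN(CCCN1CCCCC1)c1ccc(C(=O)N2CCc3ccc(OS(N)(=O)=O)cc3C2)cc1` gives 17.4% in an assay on HEK293 cells for inhibition of Steryl-sulfatase (Homo sapiens), tested at 0.1 uM; on this read-out higher numbers stand for a stronger effect at the one concentration tested and lower numbers for a weaker effect. Compound 2 `CN(C)CCN(CCN(C)C)c1ccc(C(=O)N2CCc3ccc(OS(N)(=O)=O)cc3C2)cc1` gives 3.8% in the same assay, and compound 3 `CC(C)CCN(CCC(C)C)c1ccc(C(=O)N2CCc3ccc(OS(N)(=O)=O)cc3C2)cc1` gives 47%. Compound 3 thus stands highest of the three numbers: the step of a number 29.6 percentage points higher from compound 1 to compound 3 (beyond the scatter) and the step of a number 43.2 percentage points higher from compound 2 to compound 3 (beyond the scatter) both lie beyond the scatter, while the step of a number 13.6 percentage points lower from compound 1 to compound 2 (beyond the scatter) runs the other way.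

The next step goes from compound 3 to compound 4 `CCCN(Cc1ccccc1)c1ccc(C(=O)N2CCc3ccc(OS(N)(=O)=O)cc3C2)cc1`, which is not yet measured. The change is benzyl(propyl)amino in place of diisopentylamino on an aromatic carbon. The two measured steps that reach compound 3 both replace one group on that aromatic carbon with another, and both are sizeable, so a change at this position can move the read-out by a modest to large amount. Whether the swap to benzyl(propyl)amino moves it up or down cannot be read from the measured compounds, since none of them carries a benzyl or propyl group there. The expectation is a step of roughly a number 12 percentage points lower from compound 3 to compound 4 (beyond the scatter), that is, a number somewhat below compound 3 but well above compound 2. Compound 4 is estimated at 35%, with a range from 15% to 55%.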

Compound 4, a percentage reported as inhibition, at one concentration (the size of the read-out at that concentration, not a potency): 64.8%
Estimate against measurement, compound 4: 29.8 percentage points below; the whole stated range lies below it.
By their numbers in this assay, from the lowest: compound 2; then compound 1; then compound 3; then compound 4.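

In this assay, benzyl(propyl)amino in place of diisopentylamino gives a step of a number 17.8 percentage points higher from compound 3 to compound 4 (beyond the scatter), so this position accepts a six-membered aromatic ring of carbon within the amino group, and the swap raises the number even though the heavy-atom count stays the same. The steps of a number 61 percentage points higher from compound 2 to compound 4 (beyond the scatter) and a number 47.4 percentage points higher from compound 1 to compound 4 (beyond the scatter) widen the gap between the two compounds whose amino groups carry a further amine and the two whose amino groups do not, and none of the four compounds goes against this split. No measurement here explains any of these steps.

Whether the benzyl group or the propyl group accounts for the rise stays open, as does the direction of the step from benzyl(propyl)amino to dibenzylamino, dipropylamino or a phenethyl-bearing amine. How a carboxylic acid or a methoxy group on the benzyl ring would shift the number is also open, and a read-out at one concentration does not give the potency of any of these compounds.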